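This account rests on a few compounds, and the source may have more. Where it says the series, first, only, none or still open, it means among the compounds named here.

Within the data shown here, compound 1 `Cc1ccccc1OS(=O)(=O)C1CC2OC1C(c1ccc(NC(=O)CCCCCCC(=O)O)cc1)=C2c1ccc(O)cc1` has the higher of the two numbers so far in an assay on isolated protein for inhibition of protein deacetylase HDAC6 (Homo sapiens), read by fluorescence, with a stated time of 15 min (on this read-out lower numbers stand for stronger inhibition and higher numbers for weaker inhibition), where compound 1 gives 5010 nM. Compound 2 `O=C(CCCCCCC(=O)Nc1ccc(C2=C(c3ccc(O)cc3)C3CC(S(=O)(=O)Oc4ccc(Br)cc4)C2O3)cc1)NO` carries a hydroxamic acid where compound 1 carries a carboxylic acid; in this assay compound 2 gives 230 nM, a gap beyond the scatter. Compound 3 `O=C(O)CCCCCCC(=O)Nc1ccc(C2=C(c3ccc(O)cc3)C3CC(S(=O)(=O)Oc4ccc5ccccc5c4)C2O3)cc1` keeps the carboxylic acid of compound 1 and differs only by naphthalen-2-yl in place of 2-methylphenyl on an oxygen. Among the measured compounds shown here, no measured pair isolates this change, so the expected step of a 1.3-fold lower number from compound 1 to compound 3 (0.10 log units; within the scatter) is small, likely within the scatter. Compound 3 is estimated at 4000 nM, within 1500 nM to 12000 nM.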

Compound 3, half-maximal inhibitory concentration: 8110 nM
Compound 3: the middle estimate sits 2.0-fold (0.31 log units) below what was measured; the measured number falls inside the stated range.
By their numbers in this assay, from the lowest: compound 2; then compounds 1 and 3 (each within the scatter of the next).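

Putting naphthalen-2-yl in place of 2-methylphenyl on the oxygen bound to the sulfonyl sulfur gives a 1.6-fold higher number from compound 1 to compound 3 (0.21 log units; within the scatter) in this assay. With the carboxylic acid kept, two six-membered aromatic rings therefore read the same as one at this position, within the scatter. Nothing available explains this reading.

As far as these compounds go, whether this change would read the same alongside the hydroxamic acid of compound 2 stays open. So does the effect of a pyridine ring or an aminophenyl group on this oxygen.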